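A few compounds are considered here, and "the series" means these few. Any claim that something is new, unique, unknown or untested is made for them only; others in the source may bear on it.

Compound 1 `Cc1ccccc1NS(=O)(=O)c1ccc(N2CCNC2=O)cc1` carries a 2-methylphenyl group on the sulfonamide nitrogen of the shared core. For the measured compounds named here, in a functional assay on MCF7 cells (Homo sapiens) for antiproliferative activity, read by sulforhodamine B assay, with a stated time of 48 h (on this read-out higher numbers stand for weaker inhibition and lower numbers for stronger inhibition), compound 1 gives 280 nM, the only value in this set reported as a number. Compound 2 `O=C1NCCN1c1ccc(S(=O)(=O)Nc2ccc(C3CCCCC3)cc2)cc1` carries a cyclohexyl group on an aromatic carbon; in this assay compound 2 reaches only the limit of > 1000 nM. Compound 3 `CCCCCCOc1ccc(NS(=O)(=O)c2ccc(N3CCNC3=O)cc2)cc1` carries a hexyloxy group in place of that cyclohexyl; in this assay compound 3 likewise reaches only the limit of > 1000 nM. Going by the values given here, the one step between measured compounds, a step that the two limits leave unreadable from compound 2 to compound 3, cannot be read because the limit of > 1000 nM in this assay, at which 2 of the 3 values shown sit, is where both of its compounds sit.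

Compound 4 `Cc1cccc(NS(=O)(=O)c2ccc(N3CCNC3=O)cc2)c1` differs from compound 1 by 3-methylphenyl in place of 2-methylphenyl on a sulfonamide nitrogen. Among the compounds with values here, no measured step moves a methyl group to another carbon of the same phenyl ring, so nothing in the data says how large this change should be or in which direction. Within the data shown here, compounds 2 and 3 show only that other groups on that ring end at the limit; a methyl is not compared. The expected outcome for compound 4 is a shift of a 1.4-fold higher number from compound 1 to compound 4 (0.15 log units; within the scatter), small and of unknown sign. Compound 4 is therefore estimated at 400 nM in this assay, with a likely range from 150 nM to 1500 nM.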

Compound 4, half-maximal inhibitory concentration: 190 nM
Beside the measured number, compound 4's estimate is 2.1-fold (0.32 log units) above it, within the range that was stated.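

In this assay, for the compounds shown here, 3-methylphenyl in place of 2-methylphenyl on the sulfonamide nitrogen gives a 1.5-fold lower number from compound 1 to compound 4 (0.17 log units; within the scatter), the only step in this set that can be read. Compound 1 and compound 4 therefore cannot be told apart in this assay, so these two placements of the methyl group on the phenyl ring give results that match within ordinary measurement scatter, and this position now has a comparison with numbers at both ends. The step between compound 2 and compound 3 still cannot be read, and neither compound has a number to set against the methyl compounds, only a limit of the assay: the limit of > 1000 nM in this assay, at which 2 of the 4 values shown sit.

Going by these compounds, it remains open whether a plain phenyl ring with no methyl, or an ethyl group, a chlorine atom, an amine or a carboxylic acid on that ring, would give a measurable number or would end at the limit. The compounds shown also do not tell how large a group this position can carry before the read-out reaches that limit, or why the two methyl compounds give numbers at all.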